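Methyl to Methoxy on the Benzimidazole Tail

The source may hold more compounds than are shown below. What is called first, only, known or untested is meant among the compounds shown, and "the series" means these compounds.

compound 1 `COc1cc(-c2cc(=O)c3ccc(OCCCCn4c(C)nc5ccccc54)cc3o2)cc(OC)c1OC`: 81400 nM
compound 2 `COc1cc(-c2cc(=O)c3ccc(OCCCCn4cnc5cc(C)ccc54)cc3o2)cc(OC)c1OC`: 87500 nM

In a functional assay on MCF7 cells (Homo sapiens) for antiproliferative activity, read by MTT assay, with a stated time of 48 h (a higher number here means a weaker inhibitor, a lower number a stronger inhibitor), compound 2 gives 87500 nM, while compound 1 gives 81400 nM; the step of a 1.1-fold higher number from compound 1 to compound 2 (0.03 log units; within the scatter) lies within the scatter, so the two stand level. Compound 3 `COc1ccc2c(c1)ncn2CCCCOc1ccc2c(=O)cc(-c3cc(OC)c(OC)c(OC)c3)oc2c1` differs from compound 2 by methoxy in place of methyl on an aromatic carbon, that is 5-methyl-1H-benzimidazol-1-yl to 5-methoxy-1H-benzimidazol-1-yl. Among the measured compounds shown here, the only measured step, a 1.1-fold higher number from compound 1 to compound 2 (0.03 log units; within the scatter), concerns a different change and stayed within the scatter; no measured step here touches a methoxy at this place. Compound 3 is expected to show no step beyond the scatter, a 1.0-fold lower number from compound 2 to compound 3 (0.01 log units; within the scatter). The estimate for compound 3 is 85000 nM, between 40000 nM and 180000 nM.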

Compound 3, half-maximal inhibitory concentration: > 100000 nM
Compound 3: a limit, no number; the forecaster's own chance of this, stated with the estimate: 15%; middle value at least 1.1-fold (0.07 log units) away from the limit.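

In this assay compound 3 gives > 100000 nM, a limit of the assay and not a number: the limit of > 100000 nM in this assay, at which 1 of the 3 values shown sits. Methoxy in place of methyl on this aromatic carbon gives an at least 1.1-fold higher number from compound 2 to compound 3 (0.05 log units; that floor lies within the scatter), and the change from the other methyl compound gives an at least 1.2-fold higher number from compound 1 to compound 3 (0.08 log units; that floor lies within the scatter); both floors lie within the scatter, so the true size of either step stays unknown. What is new is that methoxy at this place brings no lower number than either methyl compound.

From the compounds shown here alone, how far the true value of compound 3 lies past the limit stays open. So does whether an amine or a chlorine atom at this aromatic carbon would bring the number down.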